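The compounds below may be only part of what the source reports. "The series", "measured", "known", "first", "only" and "open" are said of these compounds alone.

Measured so far:
- compound 1, `CCOC(=O)c1c(C(F)(F)F)[n+]([O-])c2ccc(F)cc2[n+]1[O-]`: 500 nM
- compound 2, `CCOC(=O)c1c(C(F)(F)F)[n+]([O-])c2ccc(C(F)(F)F)cc2[n+]1[O-]`: 4200 nM
- compound 3, `CCOC(=O)c1c(C(F)(F)F)[n+]([O-])c2ccc(C)cc2[n+]1[O-]`: 7000 nM

All three compounds share one core and differ only in a single group on an aromatic carbon. In an ADME assay on J774 cells (Mus musculus) for cytotoxicity, read by MTT assay, with a stated time of 48 h (a lower number here means a stronger inhibitor, a higher number a weaker inhibitor), compound 1 gives 500 nM, compound 2 gives 4200 nM and compound 3 gives 7000 nM. Compound 3 has the highest of the three numbers: the step of a 14-fold higher number from compound 1 to compound 3 (1.15 log units; beyond the scatter) lies beyond the scatter, while the gap between compound 2 and compound 3, a 1.7-fold higher number from compound 2 to compound 3 (0.22 log units; within the scatter), does not, so these two cannot be told apart.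

Compound 4 is `CCOC(=O)c1c(C(F)(F)F)[n+]([O-])c2ccccc2[n+]1[O-]`. The change from compound 3 is hydrogen in place of methyl on an aromatic carbon. Within the data shown here, no measured step is of this kind, since every measured one swaps one group for another rather than for a hydrogen. The measured steps at this position do show what a change there can do: an 8.4-fold higher number from compound 1 to compound 2 (0.92 log units; beyond the scatter) and a 14-fold higher number from compound 1 to compound 3 (1.15 log units; beyond the scatter) are clear, whereas a 1.7-fold higher number from compound 2 to compound 3 (0.22 log units; within the scatter) is not. Taking the middle of the three measured numbers as the most likely outcome, compound 4 is expected to give 3500 nM in this assay, within a range of 1200 nM to 10000 nM. That estimate corresponds to a 2.0-fold lower number from compound 3 to compound 4 (0.30 log units; within the scatter), a step that may well fall within the scatter.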

Compound 4, half-maximal inhibitory concentration: 4000 nM
Compound 4: the middle estimate sits 1.1-fold (0.06 log units) below what was measured, within the range that was stated.
By their numbers in this assay, from the lowest: compound 1; then compounds 4, 2 and 3 (each within the scatter of the next).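

Hydrogen at this position cannot be told apart from methyl or trifluoromethyl in this assay: a 1.8-fold lower number from compound 3 to compound 4 (0.24 log units; within the scatter) and a 1.1-fold lower number from compound 2 to compound 4 (0.02 log units; within the scatter) both lie within the scatter. Fluoro alone stands apart from hydrogen, with an 8.0-fold higher number from compound 1 to compound 4 (0.90 log units; beyond the scatter), so with hydrogen as the baseline, fluoro is the one group of the three that departs from the unsubstituted case, while methyl and trifluoromethyl do not. No measured evidence is available to explain this difference between fluoro and the other groups.

The compounds shown leave open how chloro, bromo, methoxy or an amine would behave at this position, and so whether the low number of compound 1 belongs to fluoro alone or is shared by other groups. Also open, from the compounds shown here alone, is whether the step from hydrogen to fluoro would keep its size if the ethyl ester on the shared core were replaced by a carboxylic acid or an amide.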